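The source may report more compounds than this note shows. Statements on the series, on what has been measured and on what is new or still open speak of the compounds shown alone.

Measured compounds:
compound 1 `CCCCNc1nc(N)nc2c1CN(C)CC2` — 0.03 uM
compound 2 `CCCCNc1nc(N)nc2c1CN(Cc1cc(F)cc(F)c1)CC2` — 0.23 uM

In an assay on HEK293 cells for agonist activity at Toll-like receptor 8 (Homo sapiens), read by a luciferase reporter, with a stated time of 6 h (a lower number here means that less compound is needed, a higher number that more compound is needed for the effect), compound 2 gives 0.23 uM, the highest of the two numbers recorded. Its nearest neighbour is compound 1, which gives 0.03 uM.

Compound 3 `CCCCNc1nc(N)nc2c1CN(Cc1ccco1)CC2` is not yet measured. Its change from compound 2 is furan-2-yl in place of 3,5-difluorophenyl on a saturated chain carbon bound to an amine nitrogen in a ring. Among the compounds with values here, the one measured step that bears on this place is a 7.7-fold higher number from compound 1 to compound 2 (0.88 log units; beyond the scatter), where the aryl group was introduced at the same position. The present step does not remove the group but exchanges it for a smaller aromatic ring carrying one hydrogen-bond acceptor, so only part of that measured step is expected to be recovered, and the direction is not secure. For compound 3 a step of a 1.5-fold lower number from compound 2 to compound 3 (0.19 log units; within the scatter) is expected in this assay. Compound 3 is therefore estimated at 0.15 uM, with a range from 0.04 uM to 0.6 uM.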

Compound 3, minimum effective concentration: 0.08 uM
Estimate against measurement, compound 3: 1.9-fold (0.27 log units) above; measured number inside the range.
By their numbers in this assay, from the lowest: compound 1; then compound 3; then compound 2.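

In this assay the exchange of 3,5-difluorophenyl for furan-2-yl gives a 2.9-fold lower number from compound 2 to compound 3 (0.46 log units; beyond the scatter) and shows that the number at this position depends on which aromatic ring is present, not merely on an aromatic ring being there. Furan-2-yl in place of hydrogen on a saturated chain carbon bound to an amine nitrogen in a ring still gives a 2.7-fold higher number from compound 1 to compound 3 (0.43 log units; beyond the scatter) and so recovers only part of a 7.7-fold higher number from compound 1 to compound 2 (0.88 log units; beyond the scatter) without reaching the number of compound 1.

With only these two aromatic groups in hand, the series leaves open how a thiophen-2-yl ring, a cyclohexyl ring or a primary amine on a longer chain would read at this place. Nothing available accounts for the difference between the furan-2-yl and 3,5-difluorophenyl groups.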